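This account rests on a few compounds, and the source may have more. Where it says the series, first, only, none or still open, it means among the compounds named here.

Measured in a functional assay on the whole organism with Mus musculus as the target; on this read-out lower numbers stand for an effect already at smaller amounts and higher numbers for an effect only at larger amounts of compound:
Compound 1 `CN(c1ccncc1)n1cccc1`: > 20 mg/kg
Compound 2 `Clc1cccn1Nc1ccncc1`: > 20 mg/kg

In this assay compound 2 gives > 20 mg/kg, which is a limit of the assay and not a number. Compound 1 gives > 20 mg/kg, which is also a limit. Neither compound therefore has an exact position on the scale, and the two cannot be ranked.

Compound 3 `CN(c1ccncc1)n1cccc1Cl` has not yet been measured. It differs from compound 2 by one change: methyl in place of hydrogen on a nitrogen on an aromatic ring, with methyl in place of hydrogen on a nitrogen on an aromatic ring. Within the data shown here, no measured pair shows what this change does alone, so no firm direction can be expected. A modest step in this assay is expected, possibly none beyond the usual scatter, and another limit is quite possible. The expected change is a step that the limit leaves unreadable from compound 2 to compound 3. For compound 3 the estimated value is 25 mg/kg, with an expected range from 10 mg/kg to 60 mg/kg.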

Compound 3, dose for half-maximal effect: > 20 mg/kg
Compound 3 was reported as a limit; the forecaster's own chance of this, stated with the estimate: 60%; the middle value is on the limit's open side.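

No step can be read from compound 2 to compound 3 or from compound 1 to compound 3 in this assay, because each value is a limit of the assay and not a number: the limit of > 20 mg/kg in this assay, at which 3 of the 3 values shown sit.

The compounds shown leave open what dose gives a half-maximal effect for any of the three, and whether methyl or chloro in place of hydrogen makes any difference.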